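Swapping chloro for methyl at a measuring limit

The source may hold more compounds than are shown below. What is called first, only, known or untested is meant among the compounds shown, and "the series" means these compounds.

Measured in a functional assay on PC-3 cells (Homo sapiens) for inhibition, read by sulforhodamine B assay, with a stated time of 48 h; on this read-out higher numbers stand for weaker inhibition of growth and lower numbers for stronger inhibition of growth:
Compound 1 `Cc1ccc(-c2c(CNC(C)(C)C)c(C(=O)O)nn2-c2ccccc2)cc1`: > 688000 nM
Compound 2 `CC(C)(C)NCc1c(C(=O)O)nn(-c2ccc(Cl)cc2)c1-c1ccc(F)cc1`: > 623000 nM
Compound 3 `CC(C)(C)NCc1c(C(=O)O)nn(-c2ccc(Cl)cc2)c1-c1ccc(Cl)cc1`: > 599000 nM

Compound 3 gives > 599000 nM, which is a limit and not a number. The other two compounds also give only limits, so no exact value is known yet. Compound 4 `Cc1ccc(-c2c(CNC(C)(C)C)c(C(=O)O)nn2-c2ccc(Cl)cc2)cc1` carries methyl in place of chloro on an aromatic carbon, para to a large group (methyl in place of chloro on an aromatic carbon). For the measured compounds named here, the one measured step that bears on this swap is a step that the two limits leave unreadable from compound 2 to compound 3. Compound 4 shares the 4-methylphenyl group with compound 1. Compound 1 gives > 688000 nM, also a limit. The expected size is therefore a step that the limit leaves unreadable from compound 3 to compound 4, with no change beyond the scatter in this assay. Compound 4 is estimated at 630000 nM, with an expected range from 300000 nM to 1000000 nM.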

Compound 4, concentration for 50% growth inhibition: > 629000 nM
Compound 4 was reported as a limit (the forecaster's own chance of this, stated with the estimate: 90%); the middle value does not contradict the limit.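

Compound 4, like compound 1, compound 2 and compound 3, is reported only as a limit and not as a number, so no step among these compounds can be read. The compounds shown leave open whether exchanging chloro, fluoro, methyl or hydrogen changes growth inhibition at all.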